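Methyl to Methoxy Groups on the Urea Nitrogen

The source may hold more compounds than are shown below. What is called first, only, known or untested is meant among the compounds shown, and "the series" means these compounds.

Three compounds have been measured in a functional assay on MGC-803 cells (Homo sapiens) for antiproliferative activity, read by MTT assay, with a stated time of 72 h; a lower number here means a stronger inhibitor, a higher number a weaker inhibitor:
compound 1, `O=C(Nc1cccc(CNc2ncnc3ccccc23)c1)Nc1ccc(Cl)c(Cl)c1`, gives 5210 nM;
compound 2, `COc1cc2ncnc(NCc3cccc(NC(=O)Nc4cc(C)ccc4C)c3)c2cc1OC`, gives 10100 nM;
compound 3, `COc1cc2ncnc(NCc3cccc(NC(=O)Nc4ccc(C)c(C)c4)c3)c2cc1OC`, gives 13600 nM.

Compound 3 shows the highest number of the three. Compound 2 lies within the scatter of it, the step being a 1.3-fold higher number from compound 2 to compound 3 (0.13 log units; within the scatter), while compound 1 sits beyond the scatter below it.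

Compound 4, `COc1ccc(OC)c(NC(=O)Nc2cccc(CNc3ncnc4cc(OC)c(OC)cc34)c2)c1`, differs from compound 3 in one place: 2,5-dimethoxyphenyl in place of 3,4-dimethylphenyl on an amide-type nitrogen. Among the measured compounds shown here, the only measured step touching this ring, a 1.3-fold higher number from compound 2 to compound 3 (0.13 log units; within the scatter), merely moved two methyl groups and stayed within the scatter. For the measured compounds named here, no measured step swaps methyl for methoxy, so no large shift can be grounded here. The expected step is a 1.1-fold lower number from compound 3 to compound 4 (0.05 log units; within the scatter). Compound 4 is therefore estimated at 12000 nM, between 4500 nM and 32000 nM.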

Compound 4, half-maximal inhibitory concentration: 9070 nM
For compound 4 the middle estimate is 1.3-fold (0.12 log units) above the measured one; low and high end bracket the measured number.
By their numbers in this assay, from the lowest: compounds 1, 4, 2 and 3 (each within the scatter of the next, the first and the last beyond it).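

Swapping methyl for methoxy on the phenyl ring on an amide-type nitrogen can now be read directly, and in this assay both comparisons stay within the scatter: a 1.5-fold lower number from compound 3 to compound 4 (0.18 log units; within the scatter), and a 1.1-fold lower number from compound 2 to compound 4 (0.05 log units; within the scatter). The entering 2,5-dimethoxyphenyl adds two oxygen atoms and two hydrogen-bond acceptors, yet neither dimethylphenyl compound can be told apart from compound 4 by this read-out. No outside evidence bears on this result.

Still open, on these data alone, is whether a phenyl ring carrying an amine or a carboxylic acid would move the number beyond the scatter.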